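Notes on a halogen swap across two ring positions

The compounds below may be only part of what the source reports. "The series", "measured", "known", "first", "only" and "open" are said of these compounds alone.

Compound 1 `CC1=NN(C(=O)CCl)C(c2cc(Cl)ccc2O)C1` gives 12300 nM in a functional assay on MGC-803 cells (Homo sapiens) for antiproliferative activity, read by MTT assay, with a stated time of 48 h; on this read-out higher numbers stand for an effect only at larger amounts of compound and lower numbers for an effect already at smaller amounts. Compound 2 `CC1=NN(C(=O)CCl)C(c2cc(F)ccc2O)C1` gives 6870 nM. The change chloro in place of fluoro on an aromatic carbon produced a 1.8-fold higher number from compound 2 to compound 1 (0.25 log units; within the scatter). Compound 3 `CC1=NN(S(=O)(=O)c2ccc(F)cc2)C(c2cc(Br)ccc2O)C1` gives 15500 nM; the difference between its core and the core of compound 2 is not broken down here. Against compound 1 the two values lie within the scatter, against compound 2 beyond it. Compound 4 `CC1=NN(S(=O)(=O)c2ccc(Cl)cc2)C(c2cc(Br)ccc2O)C1` carries the same kind of change, (chloro in place of fluoro on an aromatic carbon), but at a place that is para to a large group, where the earlier place was meta to a large group and para to a hydroxy group. The expected step is a 1.3-fold higher number from compound 3 to compound 4 (0.11 log units; within the scatter), resting on a 1.8-fold higher number from compound 2 to compound 1 (0.25 log units; within the scatter), which itself lay within the scatter. Compound 4 is therefore estimated at 20000 nM, with a range from 9000 nM to 45000 nM.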

Compound 4, half-maximal effective concentration: > 60000 nM
Compound 4 ended at the assay's limit (the forecaster's own chance of this, stated with the estimate: 10%); at least 3.0-fold (0.47 log units) between middle value and limit.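

Compound 4 gives > 60000 nM in this assay, and this is a limit of the assay, not a number. On the core of compound 3, chloro in place of fluoro gives an at least 3.8-fold higher number from compound 3 to compound 4 (0.58 log units; beyond the scatter) and thus a step beyond the scatter, with its full size unread. Whether the change carries from one core to the other with the same size is not settled: the same change on two cores in this assay, a 1.8-fold higher number (0.25 log units; within the scatter) from compound 2 to compound 1 and an at least 3.8-fold higher number (0.58 log units; beyond the scatter) from compound 3 to compound 4; the limit leaves it open whether they differ

The two steps sit at different places on different cores, so the effect of the place cannot be separated from that of the core. Going by these compounds, whether a methoxy group or an amine para to a large group would give a value inside the range of the assay remains open.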